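Chloro to methoxy on a weakly inhibiting oxazinone pair

The compounds below may be only part of what the source reports. "The series", "measured", "known", "first", "only" and "open" are said of these compounds alone.

Two inhibitors are measured in an assay on isolated protein for inhibition of complement C1r subcomponent (Homo sapiens); on this read-out higher numbers stand for weaker inhibition and lower numbers for stronger inhibition: compound 1 `O=c1oc(-c2ccccc2I)nc2cccc(Cl)c12` gives 57000 nM. Compound 2 `O=c1oc(-c2ccccc2I)nc2cc(Cl)ccc12` reaches only a limit of this assay, > 62500 nM, as noted in the limit of > 62500 nM in this assay, at which 1 of the 2 values shown sits. Compound 3 `COc1ccc2c(=O)oc(-c3ccccc3I)nc2c1` differs from compound 2 by methoxy in place of chloro on an aromatic carbon. Going by the values given here, with no measured step of this kind, compound 3 is expected to remain near the limit, the step that the limit leaves unreadable from compound 2 to compound 3 being estimated as none beyond the scatter. Compound 3 is thus expected at about 70000 nM, within 20000 nM to 200000 nM.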

Compound 3, half-maximal inhibitory concentration: > 62500 nM
Compound 3: only a limit was reported (the forecaster's own chance of this, stated with the estimate: 60%); the middle value is on the limit's open side.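

Compound 2 and compound 3 both stand at a limit in this assay, so no step can be read between them: the limit of > 62500 nM in this assay, at which 2 of the 3 values shown sit. As far as these compounds go, whether methoxy in place of chloro on an aromatic carbon changes inhibition at all stays open.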